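Amide Substituent Exchange in a Cell Growth Series

The compounds below may be only part of what the source reports. "The series", "measured", "known", "first", "only" and "open" are said of these compounds alone.

Compound 2 `COc1ccc2c(=O)c(/C=C/C(=O)NCc3cccc(F)c3)coc2c1` gives 17600 nM in a functional assay on HeLa cells (Homo sapiens) for inhibition, read by MTT assay, with a stated time of 48 h (on this read-out lower numbers stand for stronger inhibition and higher numbers for weaker inhibition), the lowest of the two numbers recorded, although compound 1 `COc1cccc(NC(=O)/C=C/c2coc3cc(OC)ccc3c2=O)c1` sits within the scatter of it at 19200 nM. Compound 3 `COc1ccc(NC(=O)/C=C/c2coc3cc(O)ccc3c2=O)cc1` returns only a limit of the assay, > 100000 nM. Among the measured compounds shown here, the single measured step, a 1.1-fold lower number from compound 1 to compound 2 (0.04 log units; within the scatter), shows that exchanging the group on the amide-type nitrogen left the result essentially unchanged. Compound 4 `COc1ccc2c(=O)c(/C=C/C(=O)Nc3ccccc3C)coc2c1` carries a further exchange at the same place: 2-methylphenyl in place of 3-fluorobenzyl on an amide-type nitrogen. Since the earlier exchange on that nitrogen, a 1.1-fold lower number from compound 1 to compound 2 (0.04 log units; within the scatter), moved nothing beyond the scatter, the same is expected here, namely a 1.0-fold higher number from compound 2 to compound 4 (0.01 log units; within the scatter). The estimate for compound 4 in this assay is 18000 nM, with an expected range from 6000 nM to 60000 nM.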

Compound 4, half-maximal inhibitory concentration: 7270 nM
For compound 4 the middle estimate is 2.5-fold (0.39 log units) above the measured one, and the stated range covers the measured number.
By their numbers in this assay, from the lowest: compound 4; then compounds 2 and 1 (each within the scatter of the next). At a limit, above all of these: compound 3.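

The amide-type nitrogen proves able to move the result after all: in this assay the 2-methylphenyl group gives a 2.4-fold lower number from compound 2 to compound 4 (0.38 log units; beyond the scatter) and also a 2.6-fold lower number from compound 1 to compound 4 (0.42 log units; beyond the scatter), both modest but beyond the scatter. The earlier exchange at this place had stayed within the scatter, so the position is not indifferent to every group placed on it. Nothing shown here gives a measured reason for this shift.

From the compounds shown here alone, whether the lower number is specific to 2-methylphenyl remains open. So does the effect of an amine, a carboxylic acid or a longer chain at this nitrogen.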